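The compounds below may be only part of what the source reports. "The series", "measured", "known", "first", "only" and "open" are said of these compounds alone.

Values in a functional assay on HT-29 cells (Homo sapiens) for antiproliferative activity, read by sulforhodamine B assay, with a stated time of 72 h; a lower number here means a stronger inhibitor, a higher number a weaker inhibitor:
- compound 1 `CCCCCCCCCCCCCC(=O)NC(CO)(CO)CCc1ccc(CCCCCCCC)c2ccccc12`: > 80000 nM (a limit)
- compound 2 `CCCCCCCCc1ccc(C(O)CC(CO)(CO)NC(C)=O)c2ccccc12`: 77900 nM
- compound 3 `CC(=O)NC(CO)(CO)CCc1ccc(O)c2ccccc12`: > 80000 nM (a limit)

Compound 3 sits at > 80000 nM, a limit of the assay and not a number. It is one of the two compounds at the limit of > 80000 nM in this assay, at which 2 of the 3 values shown sit. Compound 4 `CCCCc1ccc(COc2ccc(CCC(CO)(CO)NC(C)=O)c3ccccc23)cc1` carries 4-butylbenzyl in place of hydrogen on an oxygen on an aromatic ring. Among the compounds with values here, no measured pair shows this change, so any expectation is tentative. Only compound 2, at 77900 nM, gives a number, and it offers no sign of strong inhibition. A modest move toward stronger inhibition is expected, with the estimated step being an at least 2.0-fold lower number from compound 3 to compound 4 (0.30 log units; that floor lies within the scatter). For compound 4 the expected value is 40000 nM, with an estimated range of 12000 nM to 80000 nM.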

Compound 4, half-maximal inhibitory concentration: 27100 nM
The estimate for compound 4 lay 1.5-fold (0.17 log units) above the measured number, within the range that was stated.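

In this assay, 4-butylbenzyl in place of hydrogen on an oxygen on an aromatic ring gives an at least 2.9-fold lower number from compound 3 to compound 4 (0.47 log units; beyond the scatter), the only step that can be read among these compounds. This position therefore accepts the large group with a gain in inhibition, although compound 4 remains weak at 27100 nM. The true size of the step stays open, since compound 3 is held at a limit of the assay: the limit of > 80000 nM in this assay, at which 2 of the 4 values shown sit.

From the compounds shown here alone, how much of the step belongs to the butyl chain and how much to the benzyl remains open. So does whether plain benzyl, a longer chain or an amine on that ring would move the number further.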